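The source may hold more compounds than are shown below. What is called first, only, known or untested is meant among the compounds shown, and "the series" means these compounds.

Measured so far:
compound 1 `O=C(CCC1=CCN(CCCc2ccc(Cl)cc2)C1=O)NO` — 2210 nM
compound 2 `CCOc1ccc(CCCN2CC=C(CCC(=O)NO)C2=O)cc1` — 2210 nM

For the measured compounds named here, in a functional assay on MDA-MB-231 cells (Homo sapiens) for inhibition, read by sulforhodamine B assay (on this read-out higher numbers stand for weaker inhibition of growth and lower numbers for stronger inhibition of growth), compound 2 gives 2210 nM, level with compound 1 within the scatter; the only measured step, no change at the digits printed from compound 1 to compound 2 (within the scatter), ethoxy in place of chloro on an aromatic carbon, left the read-out unchanged. Compound 3 `CC(C)(C)c1ccc(CCCN2CC=C(CCC(=O)NO)C2=O)cc1` differs from compound 2 by tert-butyl in place of ethoxy on an aromatic carbon. Going by the values given here, only that flat step bears on this change, so in this assay no move beyond the scatter is expected for compound 3, and the expected step is a 1.0-fold lower number from compound 2 to compound 3 (0.00 log units; within the scatter). Compound 3 is accordingly estimated at 2200 nM, within a range of 900 nM to 5500 nM.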

Compound 3, concentration for 50% growth inhibition: 2210 nM
Compound 3: middle estimate off by 1.0-fold (0.00 log units), on the low side; low and high end bracket the measured number.
By their numbers in this assay, from the lowest: compounds 1, 2 and 3 (each within the scatter of the next).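

In this assay the change to tert-butyl gives no change at the digits printed from compound 2 to compound 3 (within the scatter) and, against the chloro compound, no change at the digits printed from compound 1 to compound 3 (within the scatter) on this aromatic carbon, para to a large group. An all-carbon group without the hydrogen-bond acceptor of ethoxy therefore reads level with both ethoxy and chloro here. No measured property is available to account for this flat result. Still open, as far as these compounds go, is whether an amine or a carboxylic acid on this carbon would move the number beyond the scatter.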